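Methyl for Bromo on the Phenyl Ring of Compound 1

The source may hold more compounds than are shown below. What is called first, only, known or untested is meant among the compounds shown, and "the series" means these compounds.

Compound 1 `CC1(C)[C@H]2CC[C@]1(C)N(Cc1cn(-c3ccccc3Br)nn1)C(=O)C2` was tested in a functional assay on A549 cells (Homo sapiens) for inhibition, read by MTT assay, with a stated time of 24 h (on this read-out higher numbers stand for weaker inhibition and lower numbers for stronger inhibition), where compound 1 gives 130 nM. Among the three compounds measured, compound 1 has the lowest of the numbers, though the other two lie close: compound 2 `CC1(C)[C@H]2CC[C@]1(C)N(Cc1cn(-c3ccc(C#N)cc3)nn1)C(=O)C2` gives 140 nM and compound 3 `CC1(C)[C@H]2CC[C@]1(C)N(Cc1cn(-c3ccccc3O)nn1)C(=O)C2` gives 230 nM. The step of a 1.1-fold higher number from compound 1 to compound 2 (0.03 log units; within the scatter) and the step of a 1.8-fold higher number from compound 1 to compound 3 (0.25 log units; within the scatter) both fall within the scatter, as does a 1.6-fold higher number from compound 2 to compound 3 (0.22 log units; within the scatter), so none of the three stands apart from the others.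

Compound 4 `Cc1ccccc1-n1cc(CN2C(=O)C[C@@H]3CC[C@@]2(C)C3(C)C)nn1` differs from compound 1 in one place: methyl in place of bromo on an aromatic carbon. Among the compounds with values here, the measured change most like it is the one from compound 1 to compound 3, where hydroxy took the place of bromo on the same aromatic carbon, and that step was a 1.8-fold higher number from compound 1 to compound 3 (0.25 log units; within the scatter). Exchanging the whole aryl group was no different, as shown by a 1.1-fold higher number from compound 1 to compound 2 (0.03 log units; within the scatter). Since every change so far at this part of the molecule has left the read-out within the scatter, the step to compound 4 is expected to be small as well, a 1.2-fold higher number from compound 1 to compound 4 (0.06 log units; within the scatter). Compound 4 is therefore estimated to give 150 nM in this assay, within a range from 70 nM to 320 nM.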

Compound 4, half-maximal inhibitory concentration: 90 nM
Beside the measured number, compound 4's estimate is 1.7-fold (0.22 log units) above it; the range from low to high includes it.
By their numbers in this assay, from the lowest: compounds 4, 1, 2 and 3 (each within the scatter of the next, the first and the last beyond it).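

With methyl at this place, on an aromatic carbon ortho to a large group, the series in this assay shows its first separation beyond the scatter: a 2.6-fold lower number from compound 3 to compound 4 (0.41 log units; beyond the scatter) is a modest step, and it divides methyl from hydroxy. Methyl and bromo, by contrast, remain within the scatter of each other, with a 1.4-fold lower number from compound 1 to compound 4 (0.16 log units; within the scatter) as their step, and replacing the whole aryl group gives the same reading, with a 1.6-fold lower number from compound 2 to compound 4 (0.19 log units; within the scatter) also within the scatter. Only the methyl and hydroxy pair therefore reads as a real difference, since hydroxy stays within the scatter of both bromo and the 4-cyanophenyl compound, and nothing available here explains that difference.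

The compounds shown leave open how a longer chain such as ethyl, an amine or a carboxylic acid would read at this same place, and so whether methyl and bromo mark the favourable end of a wider range. They also leave open whether the gap between methyl and hydroxy would hold on any cell line other than this one.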